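Swapping the heteroaryl ring on a sulfur linker in chromone cytotoxins

The source may report more compounds than this note shows. Statements on the series, on what has been measured and on what is new or still open speak of the compounds shown alone.

Measured compounds:
Compound 1, `Cc1nnc(SCc2cc(=O)c3cc(Cl)ccc3o2)o1`: > 25000 nM
Compound 2, `Nc1nnc(SCc2cc(=O)c3cc(Cl)ccc3o2)s1`: > 25000 nM
Compound 3, `Cc1nnc(SCc2coc3ccccc3c2=O)o1`: 1400 nM

In a functional assay on HeLa cells (Homo sapiens) for cytotoxicity, read by MTT assay, with a stated time of 72 h (a lower number here means a stronger inhibitor, a higher number a weaker inhibitor), compound 1 gives only a limit of the assay, > 25000 nM. Compound 2 likewise gives only a limit, > 25000 nM, so the step that the two limits leave unreadable from compound 1 to compound 2, made by the change (5-amino-1,3,4-thiadiazol-2-yl in place of 5-methyl-1,3,4-oxadiazol-2-yl on a sulfur), cannot be read, since both values sit at the limit of > 25000 nM in this assay, at which 2 of the 3 values shown sit. Compound 3 gives a number in this assay, 1400 nM; how its core differs from the core of compound 1 is not broken down here.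

Compound 4, `Nc1nnc(SCc2coc3ccccc3c2=O)s1`, has not yet been measured. It differs from compound 3 by the change (5-amino-1,3,4-thiadiazol-2-yl in place of 5-methyl-1,3,4-oxadiazol-2-yl on a sulfur), the same kind of change as from compound 1 to compound 2, at a place described in the same words. Because the earlier step that the two limits leave unreadable from compound 1 to compound 2 gives no readable size, the step from compound 3 to compound 4 is expected to be small, a 1.8-fold higher number from compound 3 to compound 4 (0.25 log units; within the scatter), with a wide range. Compound 4 is therefore estimated at 2500 nM in this assay, between 700 nM and 12000 nM.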

Compound 4, half-maximal inhibitory concentration: > 25000 nM
Compound 4: only a limit was reported (the forecaster's own chance of this, stated with the estimate: 25%); middle value at least 10-fold (1.00 log units) away from the limit.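

In this assay, putting 5-amino-1,3,4-thiadiazol-2-yl in place of 5-methyl-1,3,4-oxadiazol-2-yl on the sulfur gives an at least 17-fold higher number from compound 3 to compound 4 (1.25 log units; beyond the scatter), so on the core of compound 3 this change costs much of the measured activity. As far as these compounds go, compound 4 gives only a limit, so the full size of this step stays unknown. The same change on the core of compound 1 cannot be read, so nothing shows whether the change has an effect of similar size on both cores, because the values of compound 1 and compound 2 are limits too: the limit of > 25000 nM in this assay, at which 3 of the 4 values shown sit.

The ring and the group on it change together, so the compounds shown leave open which of the two matters; a 5-methyl-1,3,4-thiadiazol-2-yl or a 5-amino-1,3,4-oxadiazol-2-yl group on the sulfur of the core of compound 3 would separate them. Also open, from the compounds shown here alone, is how a longer chain in place of the methyl would compare with compound 3, which gives 1400 nM.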